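Carbamoyl in place of amino on a saturated chain

A few compounds are considered here, and "the series" means these few. Any claim that something is new, unique, unknown or untested is made for them only; others in the source may bear on it.

In a functional assay on DU-145 cells (Homo sapiens) for inhibition, read by sulforhodamine B assay, with a stated time of 48 h (on this read-out lower numbers stand for stronger inhibition of growth and higher numbers for weaker inhibition of growth), the compounds gave these values:
- compound 1 `CCCCCCCCCCCC[C@@H](O)[C@H]1CC[C@H]([C@H](O)CCCCCCCCCCNC(=O)c2ccnn2C)O1` gives 100000 nM
- compound 2 `CCCCCCCCCCCC[C@@H](O)[C@H]1CC[C@H]([C@H](O)CCCCCCCCCCN(C)C(=O)c2ccnn2C)O1` gives 12900 nM
- compound 3 `CCCCCCCCCCCC[C@@H](O)[C@H]1CC[C@H]([C@H](O)CCCCCCCCCCNCc2ccnn2C)O1` gives 4370 nM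

Compound 3 stands lowest of the three on these numbers. Compound 4 `CCCCCCCCCCCC[C@@H](O)[C@H]1CC[C@H]([C@H](O)CCCCCCCCCCC(=O)Nc2ccnn2C)O1` differs from it thus: (1-methyl-1H-pyrazol-5-yl)carbamoyl in place of ((1-methyl-1H-pyrazol-5-yl)methyl)amino on a saturated chain carbon, ten or more bonds along the chain from an oxygen on a saturated carbon and a saturated ring carbon. The new group sits on a saturated chain carbon and brings back a carbonyl, which compound 1 and compound 2 also carry. Going by the values given here, two measured steps bear on this: a 23-fold lower number from compound 1 to compound 3 (1.36 log units; beyond the scatter) and a 3.0-fold lower number from compound 2 to compound 3 (0.47 log units; beyond the scatter). Neither is the same change, so a modest step to a higher number is expected in this assay, not a large one. The expected step is a 4.6-fold higher number from compound 3 to compound 4 (0.66 log units; beyond the scatter). For compound 4 the estimated value is 20000 nM, with an expected range from 5000 nM to 80000 nM.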

Compound 4, concentration for 50% growth inhibition: 100000 nM
Beside the measured number, compound 4's estimate is 5.0-fold (0.70 log units) below it; the whole stated range lies below it.
By their numbers in this assay, from the lowest: compound 3; then compound 2; then compounds 1 and 4 (each within the scatter of the next).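

In this assay, the (1-methyl-1H-pyrazol-5-yl)carbamoyl group on this saturated chain carbon loses the whole advantage of the amine, with a 23-fold higher number from compound 3 to compound 4 (1.36 log units; beyond the scatter), and it also falls short of the methylated amide, with a 7.8-fold higher number from compound 2 to compound 4 (0.89 log units; beyond the scatter). Turning the amide around changes nothing at the digits printed, with no change at the digits printed from compound 1 to compound 4 (within the scatter), so among these compounds only the methylated amide and the amine give lower numbers. Nothing measured here accounts for these steps.

Still open, on these data alone, is whether a methyl on the amide nitrogen of compound 4 would lower its number as it does for compound 1, and whether a tertiary amine or a carboxylic acid at this chain end would match compound 3.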